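The source may hold more compounds than are shown below. What is called first, only, known or untested is meant among the compounds shown, and "the series" means these compounds.

Compound 1 `Cc1cc(=O)c2c(O)c(CN3CCC(N4CCCCC4)CC3)c(O)c([C@H]3CCN(C)C[C@H]3O)c2o1`: 31%
Compound 2 `Cc1oc2c([C@H]3CCN(C)C[C@H]3O)c(O)cc(O)c2c(=O)c1C(O)c1ccc(Cl)cc1`: 3%

In a functional assay on Caco-2 cells (Homo sapiens) for inhibition, read by MTT assay, with a stated time of 48 h, tested at 10 uM (a lower number here means less inhibition of growth, a higher number more inhibition of growth at the concentration tested), compound 2 gives 3%, the lowest of the two numbers. Compound 1 gives 31%, and the gap between these two compounds lies beyond the scatter. Compound 3 `Cc1oc2c([C@H]3CCN(C)C[C@H]3O)c(O)cc(O)c2c(=O)c1C(O)c1cc(F)cc(F)c1` differs from compound 2 by 3,5-difluorophenyl in place of 4-chlorophenyl on a saturated chain carbon bound to an aromatic carbon and an oxygen on a saturated carbon, with 3,5-difluorophenyl in place of 4-chlorophenyl on a saturated chain carbon bound to an aromatic carbon and an oxygen on a saturated carbon. Among the measured compounds shown here, no measured pair tests this change, so no step beyond the scatter is expected in this assay. The expected value for compound 3 is 6%, with an estimated range of 0% to 18%. That estimate means an expected a number 3 percentage points higher from compound 2 to compound 3 (within the scatter).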

Compound 3, percent growth inhibition at one concentration: 10%
The estimate for compound 3 lay 4 percentage points below the measured number; the range from low to high includes it.
By their numbers in this assay, from the lowest: compounds 2 and 3 (each within the scatter of the next); then compound 1.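

Putting 3,5-difluorophenyl in place of 4-chlorophenyl on the saturated chain carbon gives, in this assay, a number 7 percentage points higher from compound 2 to compound 3 (within the scatter). Among the compounds shown here, this is the first reading of a change at this position alone, and it shows that these two phenyl groups cannot be told apart here. Nothing measured explains the result.

Going by these compounds, whether an unsubstituted phenyl or an amine at this position would read the same remains open. Compound 1 differs from both in more than one place, so its gap to them cannot be read as the effect of any single change.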